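Notes on the terminal aryl group of a shared core

The source may report more compounds than this note shows. Statements on the series, on what has been measured and on what is new or still open speak of the compounds shown alone.

The three measured compounds share one core and differ only in the group on the amine nitrogen in a ring. Compound 1 `Nc1scc(CN2CCN(c3ccc(Cl)cc3F)CC2)c1C(=O)c1ccc(Cl)cc1` carries a 4-chloro-2-fluorophenyl there, and in a functional assay on CHO cells with adenosine receptor A1 (Homo sapiens) as the target, read by cAMP accumulation and immunoassay, with a stated time of 6 min, tested at 10 uM (a lower number here means a stronger effect, a higher number a weaker effect of the compound at the concentration tested), compound 1 gives -81%. Compound 2 `Nc1scc(CN2CCN(c3ccccc3C(F)(F)F)CC2)c1C(=O)c1ccc(Cl)cc1` carries a 2-(trifluoromethyl)phenyl, and in this assay compound 2 gives -60%. Compound 3 `Nc1scc(CN2CCN(CCCc3ccc(Cl)cc3)CC2)c1C(=O)c1ccc(Cl)cc1` carries a 3-(4-chlorophenyl)propyl, and in this assay compound 3 gives -76%. On these numbers compound 2 stands highest, that is with the weakest effect: a number 21 percentage points higher from compound 1 to compound 2 (beyond the scatter) and a number 16 percentage points lower from compound 2 to compound 3 (beyond the scatter), both beyond the scatter, whereas a number 5 percentage points higher from compound 1 to compound 3 (within the scatter).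

Compound 4 `Nc1scc(CN2CCN(c3ccccc3Cl)CC2)c1C(=O)c1ccc(Cl)cc1` differs from compound 2 in one place: chloro in place of trifluoromethyl on an aromatic carbon. The exchange sits on an aromatic carbon of a six-membered aromatic ring of carbon only, ortho to a large group. For the measured compounds named here, no measured step exchanges chloro for trifluoromethyl, so none bears on it directly. The nearest comparison is a number 21 percentage points higher from compound 1 to compound 2 (beyond the scatter), where the halogenated phenyl gave the lower number; a partial return toward that is expected. The expected step is a number 10 percentage points lower from compound 2 to compound 4 (within the scatter). For compound 4 in this assay the estimate is -70%, with a range from -85% to -50%.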

Compound 4, a percentage reported as activity, at one concentration (the size of the read-out at that concentration, not a potency): -18%
Compound 4: the middle estimate sits 52 percentage points below what was measured; measured number above the stated range.
By their numbers in this assay, from the lowest: compounds 1 and 3 (each within the scatter of the next); then compound 2; then compound 4.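

In this assay, for the compounds shown here, the aromatic carbon that carries trifluoromethyl in compound 2 proves far more sensitive than the earlier compounds showed, with a number 42 percentage points higher from compound 2 to compound 4 (beyond the scatter) for the exchange of a group of 4 heavy atoms for one of 1 heavy atom, a step larger than any seen before. A halogen on the phenyl does not by itself go with the lower number, as compound 4 goes against that reading: the change to 2-chlorophenyl gives a number 63 percentage points higher from compound 1 to compound 4 (beyond the scatter) when it replaces 4-chloro-2-fluorophenyl and a number 58 percentage points higher from compound 3 to compound 4 (beyond the scatter) when it replaces 3-(4-chlorophenyl)propyl on the same ring nitrogen. No measurement at hand gives a cause for these steps.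

Open, going by these compounds, is whether a methyl, a methoxy or a nitrile on that same aromatic carbon would stand with compound 2 or with compound 4, which would show how the read-out tracks the group there. Also open, on these data alone, is how much of the gap to compound 1 belongs to the chloro and how much to the fluoro, which a plain 4-chlorophenyl on the same nitrogen would help to separate.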